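A few compounds are considered here, and "the series" means these few. Any claim that something is new, unique, unknown or untested is made for them only; others in the source may bear on it.

Compound 1 `COc1cc(OC)c2c(=O)cc(-c3ccc(OC4CCNCC4)cc3)oc2c1` is the starting point. In a functional assay (Homo sapiens) for antiproliferative activity, read by resazurin assay, with a stated time of 48 h, tested at 10 uM (a higher number here means a stronger effect of the compound at the concentration tested, a lower number a weaker effect), compound 1 gives 21%, the lowest of the three numbers at hand. Compound 2 `COc1cc(OC)c2c(=O)cc(-c3ccc(OCCN)cc3)oc2c1` gives 35% in this assay, and compound 3 `COc1cc(OC)c2c(=O)cc(-c3ccc(OCCCN)cc3)oc2c1` gives 39%. The step of a number 14 percentage points higher from compound 1 to compound 2 (beyond the scatter) and the step of a number 18 percentage points higher from compound 1 to compound 3 (beyond the scatter) both lie beyond the scatter, while the step of a number 4 percentage points higher from compound 2 to compound 3 (within the scatter) does not. Compound 4 `COc1cc(OC)c2c(=O)cc(-c3ccc(NCCN4CCCC4)cc3)oc2c1` has not yet been measured. (2-(pyrrolidin-1-yl)ethyl)amino in place of (piperidin-4-yl)oxy on an aromatic carbon The two steps that bear on this change are those from compound 1 to compound 2 and from compound 1 to compound 3, where piperidin-4-yl was likewise removed, once for 2-aminoethyl and once for 3-aminopropyl, and each time the number rose modestly. Going by the values given here, the change to compound 4 also removes the piperidin-4-yl and brings in a chain carrying a nitrogen ring, so a modest rise is expected, though here the oxygen leaves as well and no measured step covers that. Compound 4 is therefore expected to give 35% in this assay, within 15% to 55%. That corresponds to an expected step of a number 14 percentage points higher from compound 1 to compound 4 (beyond the scatter).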

Compound 4, a percentage reported as inhibition, at one concentration (the size of the read-out at that concentration, not a potency): 51%
For compound 4 the middle estimate is 16 percentage points below the measured one, within the range that was stated.
By their numbers in this assay, from the lowest: compound 1; then compounds 2 and 3 (each within the scatter of the next); then compound 4.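

In this assay, the (2-(pyrrolidin-1-yl)ethyl)amino group on this aromatic carbon gives a number 30 percentage points higher from compound 1 to compound 4 (beyond the scatter), and it also stands clear of the two simple aminoalkoxy chains, with a number 16 percentage points higher from compound 2 to compound 4 (beyond the scatter) and a number 12 percentage points higher from compound 3 to compound 4 (beyond the scatter). The position therefore still gives a higher number without an oxygen attached to the aromatic ring, and among the compounds shown, the group with a five-membered ring at the end of its chain gives the highest number. Nothing at hand explains this rise.

The linking atom and the chain end change together here, so the steps cannot say which of them matters; a 2-(pyrrolidin-1-yl)ethoxy group would keep the oxygen and separate the two. On these data alone, whether a piperidine, a morpholine or a dimethylamino group at the chain end would do the same also remains open.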